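The source may hold more compounds than are shown below. What is called first, only, known or untested is meant among the compounds shown, and "the series" means these compounds.

compound 1 `O=C(/C=C/c1ccc(CN2C(=O)/C(=C3\Nc4ccccc4\C3=N/O)c3cc(Cl)ccc32)cc1)NO`: 7 nM
compound 2 `O=C(NO)c1ccc(CN2C(=O)/C(=C3\Nc4ccccc4\C3=N/O)c3cc(F)ccc32)cc1`: 30 nM
compound 3 `O=C(/C=C/c1ccc(CN2C(=O)/C(=C3\Nc4ccccc4\C3=N/O)c3cc(F)ccc32)cc1)NO`: 8 nM

In a functional assay on NCI-H23 cells (Homo sapiens) for cytotoxicity, read by colorimetric assay (on this read-out higher numbers stand for weaker inhibition and lower numbers for stronger inhibition), compound 2 gives the highest number of the three, 30 nM. Compound 4 `COc1ccc2c(c1)/C(=C1/Nc3ccccc3/C1=N\O)C(=O)N2Cc1ccc(C(=O)NO)cc1` differs from compound 2 in one place, with methoxy in place of fluoro on an aromatic carbon.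

Among the measured compounds shown here, no measured compound carries methoxy, so the nearest guide is the exchange of one group for another at this same carbon, seen between compound 1 and compound 3: a 1.1-fold higher number from compound 1 to compound 3 (0.06 log units; within the scatter). The other measured step, a 3.8-fold lower number from compound 2 to compound 3 (0.57 log units; beyond the scatter), replaces hydroxycarbamoyl with 2-(hydroxycarbamoyl)ethenyl elsewhere in the molecule, so it fixes the level of compound 2 but says nothing about methoxy.

With a single guiding step, and that one between two other groups, only a small change can be expected, and the range stays wide. The expected size is a 1.2-fold higher number from compound 2 to compound 4 (0.07 log units; within the scatter), which would lie within the scatter. For compound 4 the estimated value is 35 nM, with an expected range from 14 nM to 90 nM.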

Compound 4, half-maximal inhibitory concentration: 90 nM
Compound 4: middle estimate off by 2.6-fold (0.41 log units), on the low side; the range from low to high includes it.
By their numbers in this assay, from the lowest: compounds 1 and 3 (each within the scatter of the next); then compound 2; then compound 4.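

In this assay there is a 3.0-fold higher number from compound 2 to compound 4 (0.48 log units; beyond the scatter) when methoxy takes the place of fluoro, so this aromatic carbon does respond to the group it carries. The earlier exchange at the same carbon, with a 1.1-fold higher number from compound 1 to compound 3 (0.06 log units; within the scatter) as fluoro replaced chloro, gave no sign of this, and the new step shows that a change here can go beyond the scatter. No measurement at hand bears on why methoxy and fluoro differ in this way.

On these data alone, it remains open whether a hydroxy group, an amine or a longer ether chain at this carbon would raise the number as methoxy does. As far as these compounds go, it is also open whether methoxy would have the same effect in compounds carrying 2-(hydroxycarbamoyl)ethenyl instead of hydroxycarbamoyl, the setting in which chloro and fluoro were compared.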